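This account rests on a few compounds, and the source may have more. Where it says the series, first, only, none or still open, it means among the compounds named here.

Measured so far in an ADME assay on PC-3 cells (Homo sapiens) for cytotoxicity, read by WST assay, tested at 100 uM; a lower number here means less inhibition, a higher number more inhibition at the concentration tested (going by the name of the read-out):
compound 1 `O=C(Nc1cccc(Oc2ccccn2)c1)C1CCCN(C(=O)c2cc(C(F)(F)F)cc(C(F)(F)F)c2)C1`: 0%
compound 2 `C=CCOc1cccc(NC(=O)C2CCCN(C(=O)c3cc(C(F)(F)F)cc(C(F)(F)F)c3)C2)c1`: 0%

Compound 2 stands level with compound 1 at the digits shown; its nearest neighbour is compound 1, and the step of no change at the digits printed from compound 1 to compound 2 (within the scatter) brought nothing beyond the scatter. Both measured compounds therefore sit at the bottom of the scale in this assay.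

Compound 3 `O=C(Nc1cccc(-c2cnco2)c1)C1CCCN(C(=O)c2cc(C(F)(F)F)cc(C(F)(F)F)c2)C1` has not yet been measured. Relative to compound 2 the change is 1,3-oxazol-5-yl in place of allyloxy on an aromatic carbon.

Going by the values given here, only one measured step bears on this change: the exchange on the same aromatic carbon that gave no change at the digits printed from compound 1 to compound 2 (within the scatter). That step was flat, and with both measured compounds at the floor there is no shown movement in this assay to build on. The expected step is accordingly no change at the digits printed from compound 2 to compound 3 (within the scatter), that is, none beyond the scatter. Compound 3 is estimated at 0%, with a range from 0% to 15%.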

Compound 3, a percentage reported as inhibition, at one concentration (the size of the read-out at that concentration, not a potency): 9%
The estimate for compound 3 lay 9 percentage points below the measured number; measured number inside the range.
By their numbers in this assay, from the lowest: compounds 1, 2 and 3 (each within the scatter of the next).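

Replacing the oxygen-linked groups with a directly attached aromatic ring at this place, on an aromatic carbon meta to a large group, stays within the scatter in this assay: 1,3-oxazol-5-yl for allyloxy gives (a number 9 percentage points higher from compound 2 to compound 3 (within the scatter)) and 1,3-oxazol-5-yl for (pyridin-2-yl)oxy gives (a number 9 percentage points higher from compound 1 to compound 3 (within the scatter)). Three groups of different build, with and without the linking oxygen, therefore cannot yet be told apart at this position in this read-out. No measured evidence bears on this result.

Still open, from the compounds shown here alone, is whether an amine or a carboxylic acid at this place would produce a step beyond the scatter in this assay. Also open, going by these compounds, is whether a longer alkyl chain on the oxygen would do so.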